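The source may report more compounds than this note shows. Statements on the series, on what has been measured and on what is new or still open speak of the compounds shown alone.

Measured so far in an assay on isolated protein for agonist activity at Bile acid receptor (Homo sapiens), read by TR-FRET, with a stated time of 3 h, in the absence of a further agent; on this read-out higher numbers stand for an effect only at larger amounts of compound and lower numbers for an effect already at smaller amounts:
compound 1 `O=C(O)c1cccc(NC(=O)c2ccc(Oc3ccccc3)cc2)c1` gives 97 nM
compound 2 `CC(Oc1cccc(NC(=O)c2ccc(Oc3ccccc3)cc2)c1)C(=O)O` gives > 10000 nM, which is a limit of this assay and not a number
compound 3 `COc1cccc(C(=O)Nc2cccc(C(=O)O)c2)c1` gives 1040 nM

Compound 3 holds the higher of the two numbers shown; compound 1 holds the lower one. Compound 2 sits at the limit of > 10000 nM in this assay, at which 1 of the 3 values shown sits. Compound 4 `CCOc1cccc(C(=O)Nc2cccc(C(=O)O)c2)c1` has not yet been measured in this assay. It differs from compound 3 by methyl in place of hydrogen on a saturated chain carbon bound to an oxygen on an aromatic ring. For the measured compounds named here, the only measured step, an at least 100-fold higher number from compound 1 to compound 2 (2.01 log units; beyond the scatter), alters the acid end of the molecule, not the ether end, so no measured step bears on this small change. Within the usual scatter, no real shift is expected: a 1.0-fold lower number from compound 3 to compound 4 (0.02 log units; within the scatter). Compound 4 is therefore estimated to give about 1000 nM, between 300 nM and 3500 nM.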

Compound 4, half-maximal effective concentration: 2350 nM
Estimate against measurement, compound 4: 2.4-fold (0.37 log units) below; the range from low to high includes it.
By their numbers in this assay, from the lowest: compound 1; then compound 3; then compound 4. At a limit, above all of these: compound 2.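

In this assay, the ether end of the molecule responds even to one added methyl: going from methoxy to ethoxy brings a 2.3-fold higher number from compound 3 to compound 4 (0.35 log units; beyond the scatter). For the compounds shown here, this step is modest but beyond the scatter, and it is the only measured step at this end, since the earlier one altered the acid end. Nothing among the data shown accounts for this shift.

From the compounds shown here alone, a single step sets no trend, so it remains open whether a longer chain, such as propoxy, would raise the number further. Going by these compounds, how an amine at this position would compare also remains open.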